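Cytotoxicity notes: anilide series, methyl to methoxy exchange

The source may hold more compounds than are shown below. What is called first, only, known or untested is meant among the compounds shown, and "the series" means these compounds.

Compound 1 `COc1ccc2c(=O)c(/C=C/C(=O)Nc3cccc(C)c3)coc2c1` gives 554000 nM in an ADME assay on HepG2 2.2.15 cells (Homo sapiens) for cytotoxicity, read by MTT assay, with stated times of 48 h and 9 days; a higher number here means that more compound is tolerated, a lower number that less compound is tolerated. Compound 2 `COc1ccc2c(=O)c(/C=C/C(=O)Nc3cc(C)ccc3C)coc2c1` gives 1100000 nM in this assay.

Among the measured compounds shown here, compound 1 stands at the lower of the two numbers; its only neighbour is compound 2, and the step of a 2.0-fold higher number from compound 1 to compound 2 (0.30 log units; within the scatter) lies within the scatter. Compound 3 `COc1cccc(NC(=O)/C=C/c2coc3cc(OC)ccc3c2=O)c1` is compound 1 with methoxy in place of methyl on an aromatic carbon, on the aromatic carbon meta to a large group. For the measured compounds named here, no measured step covers this exchange; the only step on that ring, from compound 1 to compound 2, stays within the scatter. In this assay compound 3 is therefore expected to move a 1.1-fold higher number from compound 1 to compound 3 (0.03 log units; within the scatter), with an estimate of 600000 nM in the range 300000 nM to 1200000 nM.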

Compound 3, half-maximal cytotoxic concentration: 1130000 nM
For compound 3 the middle estimate is 1.9-fold (0.27 log units) below the measured one; the measured number falls inside the stated range.
By their numbers in this assay, from the lowest: compounds 1, 2 and 3 (each within the scatter of the next, the first and the last beyond it).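

Among the compounds shown here, at the aromatic carbon meta to a large group, methoxy in place of methyl gives the first step in this assay printed as beyond the scatter, a 2.0-fold higher number from compound 1 to compound 3 (0.31 log units; beyond the scatter) and it is modest. The 3-methoxyphenyl and 2,5-dimethylphenyl anilides cannot be told apart, with a 1.0-fold higher number from compound 2 to compound 3 (0.01 log units; within the scatter) and so two different changes to compound 1 end at matching numbers. Nothing available explains the methoxy step. Going by these compounds, whether an amine or a carboxylic acid at this position would give a larger step stays open, as does whether methoxy elsewhere on that ring would match compound 3.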